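The compounds below may be only part of what the source reports. "The series", "measured", "known", "first", "only" and "open" are said of these compounds alone.

Measured so far in an ADME assay on PC-12 cells (Rattus norvegicus) for cytotoxicity, read by WST assay, with a stated time of 24 h; a lower number here means that less compound is tolerated, a higher number that more compound is tolerated:

Compound 1 `O=C(/C=C/c1ccccc1O)CC(=O)/C=C/c1cccc(O)c1O` gives 34000 nM
Compound 2 `O=C(/C=C/c1ccc(O)c(O)c1)CC(=O)/C=C/c1cc(O)ccc1O` gives 51000 nM
Compound 3 `O=C(/C=C/c1cc(O)ccc1O)CC(=O)/C=C/c1cccc(O)c1O` gives 53000 nM

Compound 3 stands level with the other two compounds. Both of its measured steps, a 1.6-fold higher number from compound 1 to compound 3 (0.19 log units; within the scatter) and a 1.0-fold higher number from compound 2 to compound 3 (0.02 log units; within the scatter), lie within the scatter of repeated measurements.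

Compound 4 `O=C(/C=C/c1ccccc1O)CC(=O)/C=C/c1cc(O)ccc1O` has not yet been measured. It differs from compound 3 by a single change (hydrogen in place of hydroxy on an aromatic carbon), with hydrogen in place of hydroxy on an aromatic carbon, so that 2,3-dihydroxyphenyl becomes 2-hydroxyphenyl.

The closest evidence is a 1.6-fold higher number from compound 1 to compound 3 (0.19 log units; within the scatter), where hydroxy took the place of hydrogen on an aromatic carbon. This is the same kind of change run the other way, though not at the same carbon. The other measured step, a 1.0-fold higher number from compound 2 to compound 3 (0.02 log units; within the scatter), swaps one dihydroxyphenyl for another and removes no hydroxy, so it bears on the question only loosely.

Neither step left the scatter, so at most a slight drift towards a lower number is expected. The expected change is a 1.3-fold lower number from compound 3 to compound 4 (0.10 log units; within the scatter), no larger than the scatter. For compound 4 the estimated value is 42000 nM, with an expected range from 22000 nM to 80000 nM.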

Compound 4, half-maximal cytotoxic concentration in the PC-12 assay: 38000 nM
The estimate for compound 4 lay 1.1-fold (0.04 log units) above the measured number, within the range that was stated.
By their numbers in the PC-12 assay, from the lowest: compounds 1, 4, 2 and 3 (each within the scatter of the next).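

In the PC-12 assay, taking away this one hydroxy, which sits ortho to a hydroxy group on the ring, gives a 1.4-fold lower number from compound 3 to compound 4 (0.14 log units; within the scatter), and the two other comparisons, a 1.3-fold lower number from compound 2 to compound 4 (0.13 log units; within the scatter) and a 1.1-fold higher number from compound 1 to compound 4 (0.05 log units; within the scatter), stay within the scatter as well. Among these compounds, the earlier steps had only touched a hydroxy at another carbon, so this is the first direct reading at this position, and it shows no measurable difference in how much compound the cells tolerate. In a physicochemical assay for solubility, using the shake flask method, with a stated time of 12 h (a higher number here means a more soluble compound, a lower number a less soluble compound), compound 3 gives 100000 nM, and compound 4 gives 4400 nM. The same change does separate the two compounds in the physicochemical assay, so a change that is silent in the cell assay is far from silent in solubility: the measured solubility of compound 3, 100000 nM, and of compound 4, 4400 nM, a 23-fold lower number (1.36 log units; beyond the scatter)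

Among the compounds shown here, with solubility values given for only two compounds, it remains open whether this large gap belongs to this carbon or would appear on removing a hydroxy elsewhere on the rings. Also open, from the compounds shown here alone, is what a methoxy group, an amine or a carboxylic acid at this carbon would do to either read-out, since every group compared here is a hydroxy or a hydrogen.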